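A Nitro Group Replaces Fluorine on the Amide Side

The compounds below may be only part of what the source reports. "The series", "measured", "known", "first", "only" and "open" are said of these compounds alone.

Three related compounds share a core in which a benzamide and a benzenesulfonamide hang from a central ring. Compound 1 `O=C(NCc1ccc(CNS(=O)(=O)c2ccccc2)cc1)c1cccc(F)c1` carries a 3-fluorophenyl on its carbonyl carbon, and in an assay on MDA-MB-231 cells for binding affinity to C-X-C chemokine receptor type 4 (Homo sapiens), read by immunofluorescence and microscopy, with stated times of 10 min and 30 min (on this read-out higher numbers stand for an effect only at larger amounts of compound and lower numbers for an effect already at smaller amounts), compound 1 gives 100 nM. Compound 2 `Cc1ccc(S(=O)(=O)NCc2ccc(CNC(=O)c3ccc(Cl)cc3)cc2)cc1` gives 10 nM and compound 3 `Cc1ccc(S(=O)(=O)NCc2ccc(CNC(=O)c3ccccc3Cl)cc2)cc1` gives 10 nM. So compound 1 has the highest number of the three, standing a long way from both other compounds. Between compound 2 and compound 3 the change is no change at the digits printed from compound 2 to compound 3 (within the scatter), a sign that moving a chloro group around its ring alters little.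

Compound 4 `O=C(NCc1ccc(CNS(=O)(=O)c2ccccc2)cc1)c1ccc([N+](=O)[O-])cc1` differs from compound 1 in one place: 4-nitrophenyl in place of 3-fluorophenyl on a carbonyl carbon. Within the data shown here, no measured step changes the group on the carbonyl carbon while keeping the rest of compound 1, so the only guidance is indirect, and compound 1 itself may simply sit high. Compound 4 is therefore expected to show a step of a 1.7-fold lower number from compound 1 to compound 4 (0.22 log units; within the scatter), a modest improvement at best, giving an estimated 60 nM with a range from 15 nM to 300 nM.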

Compound 4, effective concentration (reported as EC, without a stated level of effect): 100 nM
Beside the measured number, compound 4's estimate is 1.7-fold (0.22 log units) below it; the range from low to high includes it.
By their numbers in this assay, from the lowest: compounds 2 and 3 (each within the scatter of the next); then compounds 1 and 4 (each within the scatter of the next).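

In this assay, among these compounds, 4-nitrophenyl in place of 3-fluorophenyl on a carbonyl carbon gives no change at the digits printed from compound 1 to compound 4 (within the scatter) with the rest of compound 1 kept, the first measured step of this kind on that core. The entering group has more heavy atoms than the one it replaces and brings two hydrogen-bond acceptors where 3-fluorophenyl has none, yet these differences come with no readable shift in the number. No measured evidence is available to explain this result.

Since the group and its place on the ring change together, 3-nitrophenyl and 4-fluorophenyl would be needed to tell those two changes apart. As far as these compounds go, whether an amine, a carboxylic acid or a longer chain on that ring would move the number also remains open.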